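Oxolanylmethyl for ethyl on the piperidine amine of compound 3

The source may hold more compounds than are shown below. What is called first, only, known or untested is meant among the compounds shown, and "the series" means these compounds.

The measured compounds, in a functional assay on CHO cells for agonist activity at 5-hydroxytryptamine receptor 4 (Homo sapiens), read by a luciferase reporter and cAMP accumulation, with a stated time of 4 h; on this read-out higher numbers stand for an effect only at larger amounts of compound and lower numbers for an effect already at smaller amounts:
compound 1, `CC(C)c1nc(C(=O)NCC2CCN(C3CCC3)CC2)c2ccccn12`, 9.8 nM
compound 2, `COCCCN1CCC(O)(CNC(=O)c2nc(C(C)C)n3ccccc23)CC1`, 316 nM
compound 3, `CCN1CCC(NC(=O)c2nc(C(C)C)n3ccccc23)CC1`, 50 nM

Compound 3 stands in the middle of the three numbers. Compound 1 gives the lower value 9.8 nM and compound 2 the higher value 316 nM, and both gaps to compound 3 are beyond the usual scatter of this assay. All three share the same core amide, and they differ in the amine that sits in the ring and in the link between the ring and the amide.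

Compound 4, `CC(C)c1nc(C(=O)NC2CCN(CC3CCOC3)CC2)c2ccccn12`, has not yet been measured in this assay. Its difference from compound 3 is confined to one spot: oxolan-3-yl in place of methyl on a saturated chain carbon bound to an amine nitrogen in a ring. Within the data shown here, no step between measured compounds is known for this change, so the expectation rests on the spread of the three values alone. Because compound 1 gives 9.8 nM with a larger group on the same amine nitrogen, and compound 2 gives 316 nM with a longer chain there, the two measured neighbours point in opposite directions.

The expected step from compound 3 to compound 4 in this assay is estimated as a 1.4-fold lower number from compound 3 to compound 4 (0.15 log units; within the scatter), which is not beyond the scatter. Compound 4 is therefore estimated at 35 nM in this assay, within a range from 8 nM to 150 nM.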

Compound 4, half-maximal effective concentration: 25 nM
Compound 4: middle estimate off by 1.4-fold (0.15 log units), on the high side; low and high end bracket the measured number.
By their numbers in this assay, from the lowest: compound 1; then compounds 4 and 3 (each within the scatter of the next); then compound 2.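

In this assay the first step read at this position, a 2.0-fold lower number from compound 3 to compound 4 (0.30 log units; within the scatter), shows that the ethyl on the ring amine of compound 3 can give way to (oxolan-3-yl)methyl without the two numbers parting beyond the usual scatter. The earlier compounds shown here could not show this, since they differ from one another in more than one place, whereas here five heavy atoms with a ring and a hydrogen-bond acceptor enter for the single carbon of methyl, and the values of compound 3 and compound 4 still cannot be told apart. No measurement at hand bears on why these two values stand so close.

Compound 1 and compound 2 differ from compound 4 in more than one place, so steps from them cannot be read, and the compounds shown do not say how much of their distance from compound 4 comes from the amine substituent and how much from the link to the amide. Nor do they say whether the ring oxygen of oxolan-3-yl matters, which a cyclopentyl group at the same place would test.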